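This account rests on a few compounds, and the source may have more. Where it says the series, first, only, none or still open, it means among the compounds named here.

Measured in a functional assay on SNB-19 cells (Homo sapiens) for inhibition, read by sulforhodamine B assay, with a stated time of 48 h; a lower number here means that less compound is tolerated, a higher number that more compound is tolerated:
- Compound 1 `Cc1ccc(C2=NN(c3ccc(S(C)(=O)=O)cc3)C(=O)CC2)cc1`: > 100000 nM, a limit of the assay
- Compound 2 `Cc1cc(O)ccc1C1=NN(c2ccc(S(C)(=O)=O)cc2)C(=O)CC1`: > 100000 nM, a limit of the assay

Compound 2 gives no number, only the limit > 100000 nM. Compound 1 likewise gives only a limit, so neither compound has a measured value that can serve as a fixed starting point. The evidence so far amounts to this: the limit of > 100000 nM in this assay, at which 2 of the 2 values shown sit.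

The next compound is compound 3 `CCc1ccc(C2=NN(c3ccc(S(C)(=O)=O)cc3)C(=O)CC2)cc1`, which carries 4-ethylphenyl in place of 4-hydroxy-2-methylphenyl on a carbon with a double bond to nitrogen. Among the measured compounds shown here, the one measured step that changes the group at this place is a step that the two limits leave unreadable from compound 1 to compound 2. That step has no readable size to carry over.

With compound 2 resting at > 100000 nM, no step beyond the scatter is expected in this assay, and another limit is the likeliest report. The estimated step is a number no higher from compound 2 to compound 3 (the limit leaves the size open). For compound 3 the expected value is 100000 nM, with an estimated range from 50000 nM to 200000 nM.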

Compound 3, concentration lethal to 50% of the cells: > 100000 nM
Compound 3: a limit, no number (the forecaster's own chance of this, stated with the estimate: 85%); the middle value sits exactly at the limit.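

Among the compounds shown here, compound 3, like compound 1 and compound 2, gives a limit of the assay and not a number, so no step among the three can be read in this assay. The compounds shown leave open where any of them truly lies beyond that limit, and whether changing the group at this place alters the value at all.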